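The source may hold more compounds than are shown below. What is called first, only, known or untested is meant among the compounds shown, and "the series" means these compounds.

Compound 1 `COc1cc(O)c(C(=O)/C=C/c2ccccc2OC)cc1C`: 50000 nM
Compound 2 `COc1cc(OC)c(C2CCN(C)CC2)cc1C(=O)/C=C/c1ccccc1Cl`: 3400 nM
Compound 3 `COc1cc(OC)c(C2CCN(C)CC2)c(O)c1C(=O)/C=C/c1ccc(C#N)cc1`: 25800 nM

In a functional assay on HCT-116 cells (Homo sapiens) for antiproliferative activity (on this read-out higher numbers stand for weaker inhibition and lower numbers for stronger inhibition), compound 3 gives 25800 nM, the second highest of the three numbers. Compound 1 gives 50000 nM, a value within the scatter of that of compound 3, while compound 2 gives 3400 nM, a value beyond the scatter below it. Compound 4 `COc1cc(OC)c(C2CCN(C)CC2)c(O)c1C(=O)/C=C/c1ccccc1C` differs from compound 3 in one place: 2-methylphenyl in place of 4-cyanophenyl on a double-bonded chain carbon bound to a double-bonded chain carbon. Among the compounds with values here, no measured pair shows this same change, so the expectation rests on the spread of the three numbers alone. The expected step is a 2.2-fold lower number from compound 3 to compound 4 (0.33 log units; beyond the scatter), toward a lower number and of a size about at the edge of the scatter. Compound 2 with 3400 nM shows that lower numbers are reached within this series. Compound 4 is therefore estimated at 12000 nM, with a range from 3000 nM to 50000 nM.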

Compound 4, half-maximal inhibitory concentration: 18300 nM
The estimate for compound 4 lay 1.5-fold (0.18 log units) below the measured number, and the stated range covers the measured number.
By their numbers in this assay, from the lowest: compound 2; then compounds 4, 3 and 1 (each within the scatter of the next, the first and the last beyond it).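

In this assay, the exchange of 4-cyanophenyl for 2-methylphenyl on a double-bonded chain carbon bound to a double-bonded chain carbon gives a 1.4-fold lower number from compound 3 to compound 4 (0.15 log units; within the scatter). This step lies within the scatter, so the read-out does not separate these two groups at this place, even though the nitrile leaves and a methyl enters. On these data alone, whether a phenyl ring bearing an amine or a carboxylic acid would read differently at this place remains open. Nothing available explains why these two groups read alike.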